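Permeability notes: aryl swap on the oxazole-bearing series

A few compounds are considered here, and "the series" means these few. Any claim that something is new, unique, unknown or untested is made for them only; others in the source may bear on it.

Compound 1, `Cc1oc(-c2ccc(Cl)c(Cl)c2)nc1CN1CCC(C(=O)NCCCN2C[C@H](C)C[C@H](C)C2)CC1`, is examined in a physicochemical assay for permeability, using PAMPA (on this read-out lower numbers stand for lower permeability and higher numbers for higher permeability), where compound 1 gives 522 10^-6 cm/s. Two other members of the series are measured alongside it. Compound 2, `Cc1ccccc1-c1nc(CN2CCC(C(=O)NCCN3C[C@H](C)C[C@H](C)C3)CC2)c(C)o1`, gives 712 10^-6 cm/s in this assay, and compound 3, `CCCN(CCC)CCNC(=O)C1CCN(Cc2nc(-c3ccccc3C)oc2C)CC1`, gives 913 10^-6 cm/s. Compound 1 holds the lowest of the three numbers, but its gaps to compound 2 and to compound 3 are both within the scatter, so the three compounds are not ordered by this read-out.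

Among the compounds with values here, the single step measured within one structural position is a 1.3-fold higher number from compound 2 to compound 3 (0.11 log units; within the scatter). It concerns the amine at the far end of the chain, not the aryl group attached to the shared core, so it does not address the change considered here.

Compound 4, `CCc1ccccc1-c1nc(CN2CCC(C(=O)NCCCN3C[C@H](C)C[C@H](C)C3)CC2)c(C)o1`, differs from compound 1 by 2-ethylphenyl in place of 3,4-dichlorophenyl on an aromatic carbon. Compounds 1 and 2 differ in two places at once, so only their two values can be set side by side, and they lie within the scatter of each other. Within the data shown here, no measured step bears directly on the aryl exchange, and the numbers across the series stay close; the expectation for compound 4 is therefore a step of a 1.1-fold higher number from compound 1 to compound 4 (0.06 log units; within the scatter), not beyond the scatter. Compound 4 is estimated at 600 10^-6 cm/s, within a range of 350 10^-6 cm/s to 1000 10^-6 cm/s.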

Compound 4, apparent permeability: 106 10^-6 cm/s
The estimate for compound 4 lay 5.7-fold (0.75 log units) above the measured number; measured number outside the range, below it.
By their numbers in this assay, from the lowest: compound 4; then compounds 1, 2 and 3 (each within the scatter of the next).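

Placing 2-ethylphenyl in place of 3,4-dichlorophenyl on this aromatic carbon of the five-membered ring gives a 4.9-fold lower number from compound 1 to compound 4 (0.69 log units; beyond the scatter) in this assay, the only listed step in the series that stands beyond the scatter. The amine exchange at the far end of the chain, by contrast, gives a 1.3-fold higher number from compound 2 to compound 3 (0.11 log units; within the scatter), so among the listed steps only this aryl position has moved the read-out by more than the scatter, although that rests on a single step at each site. The two aryl groups match in heavy atoms, ring type, hydrogen-bond donors and acceptors and net charge, so these counts do not separate them, and nothing shown here accounts for the size of the step.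

Still open, going by these compounds, is whether the step follows the arrival of the ethyl group, the loss of the two chlorine atoms or both, since compound 4 changes these together and compounds 2 and 3 each differ from it in more than one place. Unsubstituted phenyl, 3-chlorophenyl or 4-chlorophenyl on the same carbon, with the rest of compound 1 kept, would begin to divide these possibilities.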